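Replacing a Pyridinyl Arm With a Methoxyphenoxy Ether

The source may hold more compounds than are shown below. What is called first, only, known or untested is meant among the compounds shown, and "the series" means these compounds.

Compound 1 `C=CC(=O)Nc1cccc(Nc2ncnc(Nc3ccc(-c4ccc(OC)nc4)cc3)n2)c1`: "not determined" (no result reported)
Compound 2 `C=CC(=O)Nc1cccc(Nc2ncnc(Nc3ccc(-c4cccnc4)cc3)n2)c1`: > 100000 nM

Two measured compounds share one core. For compound 1 the entry in a functional assay on Ramos cells (Homo sapiens) for antiproliferative activity, read by CCK-8 assay, with a stated time of 24 h (on this read-out higher numbers stand for weaker inhibition and lower numbers for stronger inhibition), reads "not determined" (no result reported), so no number is available for it. Compound 2 gives > 100000 nM in this assay, which is a limit of the assay and not a number. Among the compounds with values here, compound 2 thus stands at the limit of > 100000 nM in this assay, at which 1 of the 2 values shown sits, and no measured step can be drawn from it. Compound 3 `C=CC(=O)Nc1cccc(Nc2ncnc(Nc3ccc(Oc4ccc(OC)cc4)cc3)n2)c1` differs from compound 2 in one place: 4-methoxyphenoxy in place of pyridin-3-yl on an aromatic carbon. Within the data shown here, with no step between measured compounds to lean on, the size of the change cannot be read from a comparison. The step of an at least 1.6-fold lower number from compound 2 to compound 3 (0.22 log units; that floor lies within the scatter) is expected to be small, likely within the scatter, since compound 2 already sits at a limit. Compound 3 is estimated at 60000 nM in this assay, between 10000 nM and 200000 nM, with a fair chance that only a limit is reported again.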

Compound 3, half-maximal inhibitory concentration: > 100000 nM
Compound 3: only a limit was reported (the forecaster's own chance of this, stated with the estimate: 55%); at least 1.6-fold (0.22 log units) between middle value and limit.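

No step can be read from compound 2 to compound 3, since both entries are limits of the assay and not numbers: the limit of > 100000 nM in this assay, at which 2 of the 3 values shown sit. On these data alone, whether 4-methoxyphenoxy or pyridin-3-yl gives the stronger inhibition stays open, as does how compound 1 compares with either compound.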